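Side-chain swaps on the shared core: whole-animal inhibition

A few compounds are considered here, and "the series" means these few. Any claim that something is new, unique, unknown or untested is made for them only; others in the source may bear on it.

Measured so far:
compound 1 `CCCOCC1=CS(=O)(=O)c2ccccc2C1=O` gives 99.9% in a functional assay on the whole organism for inhibition, with Mus musculus as the target, at a dose of 10 mg/kg; a lower number here means less inhibition, a higher number more inhibition at the dose given (going by the name of the read-out)
compound 2 `O=C1C(COCCBr)=CS(=O)(=O)c2ccccc21` gives 100% in this assay
compound 3 `COCCOCC1=CS(=O)(=O)c2ccccc2C1=O` gives 98.2% in this assay

Compound 2 has the highest of the three numbers, yet every gap to it lies within the scatter: a number 0.1 percentage points higher from compound 1 to compound 2 (within the scatter) and a number 1.8 percentage points lower from compound 2 to compound 3 (within the scatter), as does a number 1.7 percentage points lower from compound 1 to compound 3 (within the scatter). All three numbers are level with one another.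

Compound 4 `CCNC(=O)OCC1=CS(=O)(=O)c2ccccc2C1=O` differs from compound 2 by ethylcarbamoyl in place of 2-bromoethyl on an oxygen on a saturated carbon. From the compounds shown here alone, the three measured steps each swap a single small group on a saturated chain carbon and none moved the read-out beyond the scatter; none exchanges a 2-bromoethyl for an ethylcarbamoyl, so the new group is untested here. With the read-out already near its ceiling, no step beyond the scatter is expected, a number 3 percentage points lower from compound 2 to compound 4 (within the scatter). Compound 4 is therefore estimated at 97%, from 85% to 100%.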

Compound 4, a percentage reported as inhibition, in the whole organism at one dose (the size of the read-out at that dose, not a potency): 99.3%
The estimate for compound 4 lay 2.3 percentage points below the measured number, within the range that was stated.
By their numbers in this assay, from the lowest: compounds 3, 4, 1 and 2 (each within the scatter of the next).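

At the oxygen on a saturated carbon, ethylcarbamoyl brings in the first hydrogen-bond donor and the first double bond outside aromatic rings in this side chain, yet the read-out in this assay stays level, with a number 0.7 percentage points lower from compound 2 to compound 4 (within the scatter) and a number 1.1 percentage points higher from compound 3 to compound 4 (within the scatter) and also a number 0.6 percentage points lower from compound 1 to compound 4 (within the scatter) in the series. This place therefore accepts a carbamoyl as well as the three ether side chains at this dose, and with all four values near the ceiling, no order among them can be drawn. Nothing available bears on a cause for this result.

From the compounds shown here alone, whether a carboxylic acid, an amine or a much longer chain on this oxygen would hold the number remains open. So does any separation among the four compounds at a dose where the read-out sits off its ceiling.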